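This account rests on a few compounds, and the source may have more. Where it says the series, first, only, none or still open, it means among the compounds named here.

The measured compounds and their numbers in a functional assay on DU-145 cells (Homo sapiens) for inhibition, read by trypan blue exclusion, with a stated time of 96 h; on this read-out higher numbers stand for weaker inhibition of growth and lower numbers for stronger inhibition of growth:

compound 1, `O=C(/C(=C\c1ccc(I)cc1)S(=O)(=O)c1ccc(Br)cc1)c1ccc(Br)cc1`, 1000 nM
compound 2, `O=C(/C(=C\c1ccc(F)cc1)S(=O)(=O)c1ccc(Br)cc1)c1ccc(Br)cc1`, 4000 nM
compound 3, `O=C(/C(=C\c1ccc(Br)c(O)c1)S(=O)(=O)c1ccc(Br)cc1)c1ccc(Br)cc1`, 50000 nM

Compound 3 stands at the highest of the three numbers; it lies a 13-fold higher number from compound 2 to compound 3 (1.10 log units; beyond the scatter) and a 50-fold higher number from compound 1 to compound 3 (1.70 log units; beyond the scatter).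

Compound 4, `O=C(/C(=C\c1ccc(Br)cc1)S(=O)(=O)c1ccc(Br)cc1)c1ccc(Br)cc1`, has not been measured in this assay. It differs from compound 3 in one place: hydrogen in place of hydroxy on an aromatic carbon, so that compound 4 carries a 4-bromophenyl on the double-bonded chain carbon where compound 3 carries a 4-bromo-3-hydroxyphenyl.

Among the compounds with values here, no measured step removes a hydroxy alone. Within the data shown here, the steps that bear on the change are those that reach compound 3: a 50-fold higher number from compound 1 to compound 3 (1.70 log units; beyond the scatter) and a 13-fold higher number from compound 2 to compound 3 (1.10 log units; beyond the scatter), each joining a change of halogen to the entry of the hydroxy. The halogen changes on their own were modest, as a 4.0-fold higher number from compound 1 to compound 2 (0.60 log units; beyond the scatter) shows, so most of the large steps into compound 3 goes with the hydroxy. Compound 4, with bromo in place of the iodo of compound 1 and the fluoro of compound 2 and no hydroxy, is therefore expected to sit near the numbers of those two compounds, with a large step downward in this assay. In this assay compound 1 gives 1000 nM. In this assay compound 2 gives 4000 nM. For compound 4 the estimated number is 2000 nM, with a range from 700 nM to 6000 nM, which means an expected step of a 25-fold lower number from compound 3 to compound 4 (1.40 log units; beyond the scatter).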

Compound 4, concentration for 50% growth inhibition: 10000 nM
Estimate against measurement, compound 4: 5.0-fold (0.70 log units) below, outside the stated range (above it).
By their numbers in this assay, from the lowest: compound 1; then compound 2; then compound 4; then compound 3.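

Taken alone, the loss of the hydroxy from the aromatic carbon ortho to the bromo group gives a 5.0-fold lower number from compound 3 to compound 4 (0.70 log units; beyond the scatter) in this assay and so isolates a step that the earlier compounds showed only joined to a change of halogen. This step is beyond the scatter, which ties the hydroxy to weaker inhibition of growth in this bromo pair, but it does not account for the whole gap between compound 3 and the other halogen compounds. The halogen itself carries part of that gap, with a 10-fold higher number from compound 1 to compound 4 (1.00 log units; beyond the scatter) and a 2.5-fold higher number from compound 2 to compound 4 (0.40 log units; beyond the scatter) placing the bromo compound above both the iodo and the fluoro compounds, so the three numbers do not run in the order fluoro, bromo, iodo. Nothing shown here gives a measured reason for either the hydroxy step or the halogen steps.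

Going by these compounds, the hydroxy step is known only with bromo on the same ring, so it remains open whether the same change would give a step of similar size with iodo or fluoro there. On these data alone, how a methoxy group, an amine or a chloro group would behave in place of the hydroxy or the halogen also stays open.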